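Swapping a Methyl for a Hydroxy on the Aryl Ketone Core

The source may hold more compounds than are shown below. What is called first, only, known or untested is meant among the compounds shown, and "the series" means these compounds.

Measured compounds:
compound 1, `Cc1cc(C(=O)O)ccc1OCCCCOc1ccc(C(=O)CC(C)C)c(O)c1C`: 42.1%
compound 2, `Cc1c(OCCCCOc2ccccc2C(=O)O)ccc(C(=O)CC2CCCC2)c1C`: 28%

Of the compounds shown here, two have so far been measured in an assay on HEK293 cells for positive allosteric modulation of metabotropic glutamate receptor 3 (Rattus norvegicus), read by thallium flux, with a stated time of 2.5 min; a lower number here means a smaller maximal response, a higher number a larger maximal response. Compound 1 gives 42.1%, while compound 2 gives 28%. Among the measured compounds shown here, compound 2 therefore stands lowest of the two numbers; its only neighbour, compound 1, lies higher by a gap that is beyond the usual scatter of this assay. The two, however, differ in more than one place, so their pair says nothing on its own about any single change.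

The next compound, compound 3, `Cc1c(OCCCCOc2ccccc2C(=O)O)ccc(C(=O)CC2CCCC2)c1O`, is derived from compound 2 by one change: hydroxy in place of methyl on an aromatic carbon. For the measured compounds named here, no step between measured compounds that differ in a single place is available, so there is no direct precedent for this swap. Compound 1 also carries a hydroxy group and its number sits higher, but that comparison is clouded by the other differences. A modest rise is expected, a number 8 percentage points higher from compound 2 to compound 3 (within the scatter), though it may well fall inside the scatter. Compound 3 is thus estimated at 36%, with a range from 22% to 52%.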

Compound 3, largest response reached (reported as percent of maximum), in percent of the reference or control that the assay uses: 32.9%
Compound 3: middle estimate off by 3.1 percentage points, on the high side; the measured number falls inside the stated range.
By their numbers in this assay, from the lowest: compounds 2, 3 and 1 (each within the scatter of the next, the first and the last beyond it).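

In this assay, among the compounds shown here, hydroxy in place of methyl on this aromatic carbon, ortho to a (cyclopentylmethyl)carbonyl group, gives a number 4.9 percentage points higher from compound 2 to compound 3 (within the scatter) and so provides the first comparison that isolates a single change. The swap exchanges one heavy atom for one and adds a hydrogen-bond donor and a hydrogen-bond acceptor by the count, yet compound 2 and compound 3 cannot be told apart by their maximal response, so at this position and on this core, the change has no effect that can be distinguished from the usual scatter. No supporting measurement is available to explain this result.

What the compounds shown leave open is whether a different group on this same carbon, such as a methoxy, an amine or a fluorine, would move the maximal response beyond the scatter. Going by these compounds, it also remains unknown whether the same swap would give a similar result on the core of compound 1, which would require a partner differing from it only by a methyl in place of its hydroxy.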